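The source may hold more compounds than are shown below. What is called first, only, known or untested is meant among the compounds shown, and "the series" means these compounds.

Compound 3 `CC(C(=O)N1CCCCCC1)N1CCN(S(=O)(=O)c2ccc(C(C)(C)C)cc2)CC1` stands in an ADME assay on HepG2 cells (Homo sapiens) for inhibition, with a stated time of 48 h (a lower number here means that less compound is needed, a higher number that more compound is needed for the effect), at a limit of the assay, giving > 40000 nM. Compound 1 `C[C@@H](C(=O)N1CC2CC2C1)N1CCN(S(=O)(=O)c2ccc(C(C)(C)C)cc2)CC1` likewise reaches only a limit, > 40000 nM. Compound 2 `C[C@@H](C(=O)N1CCCCC1)N1CCN(S(=O)(=O)c2ccc(C(C)(C)C)cc2)CC1` also returns a limit, > 40000 nM. Within the data shown here, the single measured step between neighbours, a step that the two limits leave unreadable from compound 1 to compound 2, cannot be read, and the whole of the evidence is the limit of > 40000 nM in this assay, at which 3 of the 3 values shown sit. Compound 4 `CC(C(=O)N1Cc2ccccc2C1)N1CCN(S(=O)(=O)c2ccc(C(C)(C)C)cc2)CC1` differs from compound 3 by a group of 9 heavy atoms (8 carbon, 1 nitrogen; one five-membered non-aromatic ring with 1 hetero atom, one six-membered aromatic ring of carbon only) in place of a group of 7 heavy atoms (6 carbon, 1 nitrogen; one seven-membered non-aromatic ring with 1 hetero atom), on a carbonyl carbon. Among the measured compounds shown here, no measured step bears on this change, and since every value shown is a limit, no movement beyond the scatter can be expected in either direction. Compound 4 is therefore expected to sit at or near the same limit, with an estimate of 40000 nM and a range from 15000 nM to 100000 nM. The expected step is a number no higher from compound 3 to compound 4 (the limit leaves the size open).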

Compound 4, half-maximal effective concentration: > 40000 nM
Compound 4: a limit, no number; the forecaster's own chance of this, stated with the estimate: 80%; the middle value lies on the limit itself.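

Compound 3 and compound 4 both return only a limit in this assay, so the step between them cannot be read. The compounds shown leave open whether any group on the carbonyl carbon would give a readable value, the whole of the evidence being: the limit of > 40000 nM in this assay, at which 4 of the 4 values shown sit.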